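This account rests on a few compounds, and the source may have more. Where it says the series, first, only, none or still open, it means among the compounds named here.

Of the compounds shown here, three built on one shared core have been measured so far. Compound 1 `CC(C)c1onc(-c2c(Cl)cccc2Cl)c1COc1ccc(N(C)C(=O)c2cccc(C(=O)O)c2)c(C(F)(F)F)n1` gives 110% in an assay on isolated protein for agonist activity at Bile acid receptor (Homo sapiens), read by FRET; a higher number here means a larger maximal response, a lower number a smaller maximal response. Compound 2 `Cc1cc(OCc2c(-c3c(Cl)cccc3Cl)noc2C(C)C)nc2ccccc12` gives 104% in this assay. Compound 3 `CC(C)c1onc(-c2c(Cl)cccc2Cl)c1COc1ccc(N(C)Cc2ccc(CCC(=O)O)cc2)c(C(F)(F)F)n1` gives 96% in this assay, the smallest of the three numbers, though its gap to compound 2 lies within the usual scatter. Within the data shown here, the one step measured between neighbours in structure is a number 14 percentage points lower from compound 1 to compound 3 (beyond the scatter), a modest drop.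

Compound 4 `CC(C)c1onc(-c2c(Cl)cccc2Cl)c1COc1ccc(N(C)Cc2ccc(OCC(=O)O)cc2)c(C(F)(F)F)n1` has not been measured. It differs from compound 3 in one place: carboxymethoxy in place of 2-carboxyethyl on an aromatic carbon. Among the measured compounds shown here, the only measured step, from compound 1 to compound 3, concerns a different part of the molecule, so no measured step bears directly on this exchange of one acid-bearing chain for another of the same size. The expectation for compound 4 is therefore a step of no change at the digits printed from compound 3 to compound 4 (within the scatter), that is, no change beyond the scatter. The estimated value of compound 4 in this assay is 96%, within a range from 80% to 112%.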

Compound 4, largest response reached (reported as efficacy), in percent of the reference or control that the assay uses: 90%
For compound 4 the middle estimate is 6 percentage points above the measured one; measured number inside the range.
By their numbers in this assay, from the lowest: compounds 4, 3, 2 and 1 (each within the scatter of the next, the first and the last beyond it).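

Exchanging 2-carboxyethyl for carboxymethoxy on this aromatic carbon, para to a large group, gives in this assay a number 6 percentage points lower from compound 3 to compound 4 (within the scatter), so an acid chain joined to the ring through oxygen cannot be told apart here from one joined through carbon. The step of a number 20 percentage points lower from compound 1 to compound 4 (beyond the scatter) also stays modest, so 4-(carboxymethoxy)benzyl, like 4-(2-carboxyethyl)benzyl, keeps much of the maximal response seen with the (3-carboxyphenyl)carbonyl group on that nitrogen. Nothing available explains the size of either step.

On these data alone, whether a longer chain, such as 3-carboxypropyl, would keep this response at the same aromatic carbon remains open. So does the outcome of replacing the carboxylic acid with a tetrazole or an amine, and this read-out, the largest response reached, says nothing about the concentration needed to reach it.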